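The source may hold more compounds than are shown below. What is called first, only, known or untested is meant among the compounds shown, and "the series" means these compounds.

Compound 1 `Cc1ccccc1S(=O)(=O)NC(=O)c1ccc(Nc2nc(NC3(c4ccc(Cl)cc4)CC3)nc(OCC(F)(F)F)n2)cc1`, compound 2 `CC(C)C(=O)NCCS(=O)(=O)NC(=O)c1ccc(Nc2nc(NC3(c4ccc(Cl)cc4)CC3)nc(OCC(F)(F)F)n2)cc1` and compound 3 `O=C(NS(=O)(=O)CCNC(=O)C1CC1)c1ccc(Nc2nc(NC3(c4ccc(Cl)cc4)CC3)nc(OCC(F)(F)F)n2)cc1` share one core and differ only in the group on the sulfonyl sulfur. In a physicochemical assay for permeability, using PAMPA, at pH 7.4 (a higher number here means that the compound crosses the layer faster, a lower number that the compound crosses the layer more slowly), compound 1 gives 265 nm/s, compound 2 gives 13 nm/s and compound 3 gives 1 nm/s. Compound 2 stands second highest of the three. The measured steps are a 20-fold lower number from compound 1 to compound 2 (1.31 log units; beyond the scatter), a 13-fold lower number from compound 2 to compound 3 (1.11 log units; beyond the scatter) and a 270-fold lower number from compound 1 to compound 3 (2.42 log units; beyond the scatter).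

Compound 4 `NCCS(=O)(=O)NC(=O)c1ccc(Nc2nc(NC3(c4ccc(Cl)cc4)CC3)nc(OCC(F)(F)F)n2)cc1` differs from compound 2 by hydrogen in place of isopropylcarbonyl on an amine nitrogen. Among the compounds with values here, no measured step removes this group; the only steps touching the same chain were both large and downward, and nothing here points upward. A further downward step is therefore expected, a 4.3-fold lower number from compound 2 to compound 4 (0.64 log units; beyond the scatter). Compound 4 is estimated at 3 nm/s, with a range from 0.5 nm/s to 15 nm/s.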

Compound 4, apparent permeability: 153 nm/s
Beside the measured number, compound 4's estimate is 51-fold (1.71 log units) below it; measured number outside the range, above it.
By their numbers in this assay, from the lowest: compound 3; then compound 2; then compounds 4 and 1 (each within the scatter of the next).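

In this assay, within the data shown here, the earlier steps only went down when 2-methylphenyl gave way to an acylated chain, but removing the acyl group from the amine nitrogen reverses this, with a 12-fold higher number from compound 2 to compound 4 (1.07 log units; beyond the scatter) and with a 150-fold higher number from compound 3 to compound 4 (2.18 log units; beyond the scatter) as the matching step from the cyclopropylcarbonyl compound. The comparison with the aryl compound gives a 1.7-fold lower number from compound 1 to compound 4 (0.24 log units; within the scatter) and so a chain on the sulfonyl sulfur does not by itself bring a low number here. Nothing available explains this recovery.

Going by these compounds, whether a dimethylamino group or a longer chain ending in a free amine would give a similar number stays open. So does the effect of a smaller acyl group, such as acetyl, on the amine nitrogen.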